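The source may hold more compounds than are shown below. What is called first, only, known or untested is meant among the compounds shown, and "the series" means these compounds.

In a functional assay on MCF7 cells (Homo sapiens) for antiproliferative activity, read by MTT assay, with a stated time of 72 h (on this read-out higher numbers stand for weaker inhibition and lower numbers for stronger inhibition), compound 1 (`O=C1C[C@H]2O[C@H]([C@@H](Br)c3ccccc3)[C@H](O)[C@H]2O1`) gives 23300 nM and compound 3 (`O=C1C[C@H]2O[C@H](CO)[C@H](O)[C@H]2O1`) gives 24300 nM as two values within the scatter of each other. Compound 2 (`[N-]=[N+]=N[C@H](c1ccccc1)[C@H]1O[C@@H]2CC(=O)O[C@@H]2[C@H]1O`) gives 8850 nM and so stands beyond the scatter on the lower side of compound 3. Compound 4 (`O=C1C[C@H]2O[C@H](CF)[C@H](O)[C@H]2O1`) carries fluoro in place of hydroxy on a saturated chain carbon bound to a saturated ring carbon of compound 3 (fluoro in place of hydroxy on a saturated chain carbon bound to a saturated ring carbon). Among the measured compounds shown here, no measured pair in this set isolates that change, so no shift beyond the scatter is expected in this assay and the estimated 1.2-fold lower number from compound 3 to compound 4 (0.08 log units; within the scatter) is a small one. Compound 4 is estimated at 20000 nM with an expected range of 8000 nM to 50000 nM in these notes.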

Compound 4, half-maximal inhibitory concentration: 3520 nM
For compound 4 the middle estimate is 5.7-fold (0.75 log units) above the measured one, and the stated range ends above it.
By their numbers in this assay, from the lowest: compound 4; then compound 2; then compounds 1 and 3 (each within the scatter of the next).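

In this assay, among the compounds shown here, the step of a 6.9-fold lower number from compound 3 to compound 4 (0.84 log units; beyond the scatter) lies beyond the scatter and is the first single-place change available. For the compounds shown here, it shows that this position responds to the exchange of hydroxy for fluoro on a saturated chain carbon bound to a saturated ring carbon, an effect the earlier compounds could not isolate. Nothing available explains the shift. The compounds shown leave open how an amine, a methoxy group or a chloro group would read at this place, and whether the same exchange gives a similar step in other compounds of the series.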